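One Halogen for Another: Compound 1 to Compound 4

The source may report more compounds than this note shows. Statements on the series, on what has been measured and on what is new or still open speak of the compounds shown alone.

Compound 1 `N#C[Se]c1ccc(NC(=O)Oc2ccc(F)cc2)cc1` was tested in an ADME assay on BEAS-2B cells (Homo sapiens) for cytotoxicity, read by MTT assay, with a stated time of 72 h (a higher number here means a weaker inhibitor of growth, a lower number a stronger inhibitor of growth), where compound 1 gives 19800 nM. Two companions were measured alongside it. Compound 3 `CCOC(=O)Nc1ccc([Se]C#N)cc1` gives 21700 nM, and compound 2 `O=C(Nc1ccc([Se][Se]c2ccc(NC(=O)OCc3ccc([N+](=O)[O-])cc3)cc2)cc1)OCc1ccc([N+](=O)[O-])cc1` gives 6300 nM. Among these three numbers compound 1 holds the second highest place. Its nearest neighbour is compound 3, whose number sits within the usual scatter of compound 1, so the two cannot be told apart on this evidence. The furthest is compound 2, whose number is lower than that of compound 1 by a margin that does lie beyond the scatter.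

Compound 4 `N#C[Se]c1ccc(NC(=O)Oc2ccc(Cl)cc2)cc1` has not yet been measured. It differs from compound 1 in one place only: chloro in place of fluoro on an aromatic carbon. Among the measured compounds shown here, no measured pair in this set differs by the same change, so there is no directly comparable step to lean on.

The account expects the step from compound 1 to compound 4 in this assay to be small, most likely not beyond the scatter, with at most a slight move toward a lower number, a 1.3-fold lower number from compound 1 to compound 4 (0.12 log units; within the scatter). On that basis compound 4 is estimated at 15000 nM, with a likely range from 7000 nM to 35000 nM.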

Compound 4, concentration for 50% growth inhibition: 9300 nM
Compound 4: the middle estimate sits 1.6-fold (0.21 log units) above what was measured, and the stated range covers the measured number.
By their numbers in this assay, from the lowest: compounds 2 and 4 (each within the scatter of the next); then compounds 1 and 3 (each within the scatter of the next).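

In this assay, the aromatic carbon para to a large group proves able to register a change: chloro in place of fluoro gives a 2.1-fold lower number from compound 1 to compound 4 (0.33 log units; beyond the scatter), a modest step, but one that lies beyond the scatter. Among the compounds shown here, the earlier compounds could not show this, since no two of them differed in one place only, so this is the first reading of what a single exchange does on the core of compound 1, and it rests on one pair of compounds alone. Nothing available here accounts for the size or direction of this step, and a single exchange of one halogen for another cannot by itself separate one possible explanation from another.

The compounds shown leave open how far this position tolerates other groups, such as a bromo, a methyl, a methoxy or an amine on the same aromatic carbon, and whether the numbers would continue in the same direction. They also leave open whether chloro in place of fluoro would give a step of similar size on a different core or at another place on this ring.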